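Cyano gives way to 2-phenylethynyl

The source may hold more compounds than are shown below. What is called first, only, known or untested is meant among the compounds shown, and "the series" means these compounds.

Measured in an ADME assay on L1210/0 cells (Mus musculus) for cytotoxicity, with a stated time of 48 h; a lower number here means a stronger inhibitor, a higher number a weaker inhibitor:
- compound 1 `O=c1[nH]c(=O)n([C@H]2C[C@H](O)[C@@H](CO)O2)cc1CO` gives 9180 nM
- compound 2 `COC1=C(OC)/C(=C\Cn2cnc3c(N)ncnc32)OC1=O` gives > 200000 nM (a limit)
- compound 3 `N#Cc1cn([C@H]2C[C@H](O)[C@@H](CO)O2)c(=O)[nH]c1=O` gives > 200000 nM (a limit)

Compound 3 has no number, only the limit > 200000 nM. Two of the values share this ceiling: the limit of > 200000 nM in this assay, at which 2 of the 3 values shown sit. Compound 4 `O=c1[nH]c(=O)n([C@H]2C[C@H](O)[C@@H](CO)O2)cc1C#Cc1ccccc1` carries 2-phenylethynyl in place of cyano on an aromatic carbon. Within the data shown here, the one measured step at this place is an at least 21-fold higher number from compound 1 to compound 3 (1.33 log units; beyond the scatter), and it was large, but it ends at a limit and so gives only a bound. Among the measured compounds shown here, no measured step brings in 2-phenylethynyl. In this assay a modest move towards a lower number is therefore expected, with compound 4 probably staying weak, and the estimated change is an at least 2.2-fold lower number from compound 3 to compound 4 (0.34 log units; beyond the scatter). For compound 4 the estimated value is 90000 nM, with an expected range from 20000 nM to 200000 nM.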

Compound 4, half-maximal inhibitory concentration: > 200000 nM
Compound 4 was reported as a limit; the forecaster's own chance of this, stated with the estimate: 45%; at least 2.2-fold (0.34 log units) between middle value and limit.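

At this aromatic carbon in this assay, hydroxymethyl remains the only group shown with a readable value. Replacing it with 2-phenylethynyl gives an at least 21-fold higher number from compound 1 to compound 4 (1.33 log units; beyond the scatter), the same bound as replacing it with cyano, an at least 21-fold higher number from compound 1 to compound 3 (1.33 log units; beyond the scatter). The step between compound 3 and compound 4 cannot be read, since both values are limits: the limit of > 200000 nM in this assay, at which 3 of the 4 values shown sit.

As far as these compounds go, how compound 3 and compound 4 actually compare stays open. So does whether an aminomethyl group or a carboxylic acid at this carbon would give a readable value.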